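Benzamides on a shared core: bromo to phenyl step

The compounds below may be only part of what the source reports. "The series", "measured", "known", "first", "only" and "open" are said of these compounds alone.

Measured so far:
Compound 1, `COc1cccc(OC)c1C(=O)Nc1nnc(-c2ccc(Cl)cc2)s1`: in a functional assay on the whole organism (integument) for inhibition, with Chilo suppressalis as the target, read by scintillation counting, with a stated time of 72 h, in the presence of a further agent that is not named here (a higher number here means a weaker inhibitor, a lower number a stronger inhibitor), compound 1 gives 58.9 nM.
Compound 2, `COc1cccc(OC)c1C(=O)Nc1nnc(-c2ccc(C(C)C)cc2)s1`: in this assay compound 2 gives 182 nM.
Compound 3, `COc1cccc(OC)c1C(=O)Nc1nnc(-c2ccc(Br)cc2)s1`: in this assay compound 3 gives 45.7 nM.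

Compound 3 has the lowest number of the three, but its separation from compound 1 is only a 1.3-fold lower number from compound 1 to compound 3 (0.11 log units; within the scatter), so the two halogen compounds cannot be ordered. Compound 2 alone stands apart: a 4.0-fold lower number from compound 2 to compound 3 (0.60 log units; beyond the scatter).

Compound 4, `COc1cccc(OC)c1C(=O)Nc1nnc(-c2ccc(-c3ccccc3)cc2)s1`, is not yet measured. The change from compound 3: phenyl in place of bromo on an aromatic carbon.

Among the measured compounds shown here, two measured steps bear on this. The first is a 3.1-fold higher number from compound 1 to compound 2 (0.49 log units; beyond the scatter); the second is a 4.0-fold lower number from compound 2 to compound 3 (0.60 log units; beyond the scatter). In both, the compound carrying a halogen on that aromatic carbon gives the lower number and the compound carrying isopropyl the higher one. Phenyl is likewise a carbon-only group at the same place, and with six heavy atoms it is larger than isopropyl. Compound 4 is therefore expected to give a higher number than compound 3 in this assay, a modest step beyond the scatter, estimated as a 4.4-fold higher number from compound 3 to compound 4 (0.64 log units; beyond the scatter). The estimate for compound 4 is 200 nM, with a range from 70 nM to 600 nM.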

Compound 4, half-maximal inhibitory concentration: 117 nM
Compound 4: the middle estimate sits 1.7-fold (0.23 log units) above what was measured, within the range that was stated.
By their numbers in this assay, from the lowest: compounds 3, 1, 4 and 2 (each within the scatter of the next, the first and the last beyond it).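

In this assay phenyl at this aromatic carbon separates from bromo (a 2.6-fold higher number from compound 3 to compound 4 (0.41 log units; beyond the scatter)) but not from the other two groups: both the chloro comparison (a 2.0-fold higher number from compound 1 to compound 4 (0.30 log units; within the scatter)) and the isopropyl comparison (a 1.6-fold lower number from compound 2 to compound 4 (0.19 log units; within the scatter)) stay within the scatter. The earlier reading, with halogen compounds giving the lower number and carbon-only groups the higher, therefore holds for bromo against phenyl. Compound 1 and compound 4 go against it as a clean split. These two compounds cannot be ordered. Compound 4 also shows that this position accepts an aromatic ring of six carbons without the number leaving the span already set by compound 2 and compound 3, so the heavy-atom count of the group does not order these compounds, and no measurement shown here gives a reason for the step.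

Going by these compounds, whether an amine, a carboxylic acid or a longer chain such as hexyl at this aromatic carbon would stay in the same span remains open. On these data alone, all four compounds also share one core and one benzamide, so it is equally open whether these steps would carry over to a compound changed elsewhere.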